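Ester Side Chain Swapped for Hydrazide in Microsomal Stability

This account rests on a few compounds, and the source may have more. Where it says the series, first, only, none or still open, it means among the compounds named here.

In an ADME assay on microsomes from liver (Homo sapiens) for metabolic stability, read by LC-MS, using NADPH, with a stated time of 45 min, tested at 1 uM (on this read-out lower numbers stand for a shorter-lived compound and higher numbers for a longer-lived compound), compound 1 `COCCOC(=O)c1cc(N)c(Nc2ccc(C#N)cc2)cc1Oc1c(C)cc(/C=C/C#N)cc1C` gives 0.317 h. Compound 2 `Cc1cc(/C=C/C#N)cc(C)c1Oc1cc(Nc2ccc(C#N)cc2)c(N)cc1C(=O)OCCC#N` gives 0.283 h, and the step of a 1.1-fold lower number from compound 1 to compound 2 (0.05 log units; within the scatter) lies within the scatter, so the two compounds stand level. Compound 3 `Cc1cc(/C=C/C#N)cc(C)c1Oc1cc(Nc2ccc(C#N)cc2)c(N)cc1C(=O)NN` differs from compound 2 in one place: aminoamino in place of 2-cyanoethoxy on a carbonyl carbon. Within the data shown here, the only measured step alters the 2-cyanoethoxy chain itself and leaves the carbonyl carbon's substituent type unchanged, so no measured step bears directly on this change. The expected step of a 1.1-fold higher number from compound 2 to compound 3 (0.03 log units; within the scatter) is therefore small, with wide uncertainty. Compound 3 is estimated at 0.3 h, between 0.1 h and 0.9 h.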

Compound 3, half-life: 0.6 h
The estimate for compound 3 lay 2.0-fold (0.30 log units) below the measured number; the measured number falls inside the stated range.
By their numbers in this assay, from the lowest: compounds 2, 1 and 3 (each within the scatter of the next, the first and the last beyond it).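

In this assay, the group on the carbonyl carbon proves able to shift the number: aminoamino in place of 2-cyanoethoxy gives a modest change beyond the scatter (a 2.1-fold higher number from compound 2 to compound 3 (0.33 log units; beyond the scatter)). Against 2-methoxyethoxy, the same replacement stays within the scatter (a 1.9-fold higher number from compound 1 to compound 3 (0.28 log units; within the scatter)), so the gain is clear against only one of the two esters. Nothing measured here accounts for the shift. The compounds shown leave open how a simple amine, a carboxylic acid or a longer chain on this carbonyl carbon would compare.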